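Chloro for Methyl on the Aryl Ring of Compound 1

The source may report more compounds than this note shows. Statements on the series, on what has been measured and on what is new or still open speak of the compounds shown alone.

Compound 1, `CC(=O)NN1C(=O)C(Cc2ccccc2)=NN2C1=NN(C(C)=O)C2(C)c1ccc(C)cc1`, gives 6.62 nM.
Compound 2, `COc1ccc(CC2=NN3C(=NN(C(C)=O)C3(C)c3ccc(C)cc3)N(N(C(C)=O)C(C)=O)C2=O)cc1`, gives 10.4 nM.

Both numbers come from an assay on microsomes from liver for inhibition of cytochrome P450 1A1 (Rattus norvegicus), read by fluorescence, with a stated time of 10 min; a higher number here means a weaker inhibitor, a lower number a stronger inhibitor. Compound 1 holds the smaller of the two numbers, but its gap to compound 2 falls within the scatter of repeated measurements, so the two compounds cannot be told apart on this evidence, and neither can be called the stronger inhibitor.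

Compound 3, `CC(=O)NN1C(=O)C(Cc2ccccc2)=NN2C1=NN(C(C)=O)C2(C)c1ccc(Cl)cc1`, is the next compound. It differs from compound 1 by one change: chloro in place of methyl on an aromatic carbon. For the measured compounds named here, no measured pair shows this particular swap, so nothing in the numbers at hand tells how large its effect is. With only the two measured compounds, which sit close together, the expectation is that the step from compound 1 to compound 3 will be small, a 1.1-fold higher number from compound 1 to compound 3 (0.02 log units; within the scatter), and will stay within the scatter in either direction. On that basis compound 3 is estimated at 7 nM, with a range from 3 nM to 16 nM.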

Compound 3, half-maximal inhibitory concentration: 5.69 nM
For compound 3 the middle estimate is 1.2-fold (0.09 log units) above the measured one; low and high end bracket the measured number.
By their numbers in this assay, from the lowest: compounds 3, 1 and 2 (each within the scatter of the next).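

For the compounds shown here, this is the first measured swap at this place, an aromatic carbon para to a large group, and in this assay it reads as a 1.2-fold lower number from compound 1 to compound 3 (0.07 log units; within the scatter) on the core of compound 1. The 4-methylphenyl and 4-chlorophenyl versions therefore cannot be told apart in this measurement, so on this core, chloro can stand in place of methyl here with no difference that the data can resolve. Nothing measured on either group bears on this result.

Only these two groups have been compared at this place, so the result says nothing about how an amine, a carboxylic acid or a longer chain such as butyl would read there. Going by these compounds, whether chloro for methyl would also give so small a step on the core of compound 2 remains open.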